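The source may hold more compounds than are shown below. What is called first, only, known or untested is meant among the compounds shown, and "the series" means these compounds.

Compound 1, with the structure `C/N=C(/S)C1=CC(C)(C)Oc2ccc([N+](=O)[O-])cc21`, is examined in a functional assay on the whole organism (aorta) with Rattus norvegicus as the target (on this read-out higher numbers stand for larger maximal responses and lower numbers for smaller maximal responses), where compound 1 gives 63.5%. Its companion compound 2, `C/N=C(/S)C1=CC(C)(C(F)(F)F)Oc2ccc([N+](=O)[O-])cc21`, gives 62.5% in this assay; the step of a number 1 percentage points lower from compound 1 to compound 2 (within the scatter) is within the scatter, so the two values cannot be told apart, and compound 1 is simply one of two near-identical readings. The unmeasured compound 3, `CNC(=O)C1=CC(C)(C)Oc2ccc([N+](=O)[O-])cc21`, differs from compound 1 as follows: a group of 4 heavy atoms (2 carbon, 1 nitrogen, 1 oxygen; no ring) in place of a group of 4 heavy atoms (2 carbon, 1 nitrogen, 1 sulfur; no ring), on a double-bonded ring carbon. Among the compounds with values here, the only measured step, the trifluoromethyl in place of methyl on a saturated ring carbon, sits at a different place and says nothing about the exchange on the double-bonded ring carbon, so no measured step bears on this change. In the absence of such evidence, the step of a number 8.5 percentage points lower from compound 1 to compound 3 (within the scatter) is expected to be modest, with a somewhat smaller maximal response held as the more likely direction. The maximal response of compound 3 in this assay is therefore estimated at 55%, with a range from 30% to 80%.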

Compound 3, intrinsic activity: the largest response reached, in percent of the reference agonist's: 61%
Compound 3: the middle estimate sits 6 percentage points below what was measured; the measured number falls inside the stated range.
By their numbers in this assay, from the lowest: compounds 3, 2 and 1 (each within the scatter of the next).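

In this assay, the exchange on the double-bonded ring carbon, methylcarbamoyl for the group that carries sulfur, reads as a number 2.5 percentage points lower from compound 1 to compound 3 (within the scatter), so on this read-out the sulfur and oxygen forms of the group cannot be told apart. The earlier pair spoke only of the saturated ring carbon, and this result extends the picture of near-identical readings to a second place on the shared core, with the group's counted hydrogen-bond donors and acceptors the same on both sides of the exchange. Nothing on hand offers an explanation for this result.

From the compounds shown here alone, whether the maximal response holds with quite different groups on this carbon, such as a carboxylic acid, a nitrile or a longer chain in place of the methyl of methylcarbamoyl, stays open. Also open, going by these compounds, is how trifluoromethyl on the saturated ring carbon would read together with methylcarbamoyl.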